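Diketopiperazine bis-benzylidene series: cytotoxicity notes

The compounds below may be only part of what the source reports. "The series", "measured", "known", "first", "only" and "open" are said of these compounds alone.

Measured so far:
compound 1, `COc1ccccc1/C=c1/[nH]c(=O)/c(=C\c2ccccc2OC)[nH]c1=O`: "not active" (no number reported)
compound 2, `C=CCn1c(=O)/c(=C\c2cccc(F)c2)[nH]c(=O)/c1=C\c1ccccc1OC`: 4100 nM
compound 3, `C=CCn1c(=O)/c(=C\c2cc(F)ccc2C)[nH]c(=O)/c1=C\c1ccccc1OC`: 1800 nM

In a functional assay on K562 cells (Homo sapiens) for cytotoxicity, read by CCK-8 assay, with a stated time of 72 h (on this read-out lower numbers stand for stronger inhibition and higher numbers for weaker inhibition), compound 3 holds the lowest number of the two reported; compound 2 sits above it, the difference being a 2.3-fold lower number from compound 2 to compound 3 (0.36 log units; beyond the scatter). Compound 1 returns no number at all in this assay.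

Compound 4, `C=CCn1c(=O)/c(=C\c2ccccc2OC)[nH]c(=O)/c1=C\c1ccccc1OC`, differs from compound 3 by 2-methoxyphenyl in place of 5-fluoro-2-methylphenyl on a double-bonded chain carbon bound to an aromatic carbon. No measured step swaps one aryl for another, so the single step shown, methyl in place of hydrogen, does not bear directly on this change. Compound 4 carries two 2-methoxyphenyl groups, as does compound 1, which gave no number; compound 4 additionally carries the allyl group of compounds 2 and 3. The expected move from compound 3 is a 3.3-fold higher number from compound 3 to compound 4 (0.52 log units; beyond the scatter), toward a higher number. Compound 4 is estimated at 6000 nM, range 2000 nM to 20000 nM.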

Compound 4, half-maximal inhibitory concentration: 7400 nM
Compound 4: the middle estimate sits 1.2-fold (0.09 log units) below what was measured; measured number inside the range.
By their numbers in this assay, from the lowest: compound 3; then compounds 2 and 4 (each within the scatter of the next).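

Within the data shown here, replacing 5-fluoro-2-methylphenyl with 2-methoxyphenyl on a double-bonded chain carbon bound to an aromatic carbon gives a 4.1-fold higher number from compound 3 to compound 4 (0.61 log units; beyond the scatter) in this assay, the first aryl-for-aryl exchange at this place with a change beyond the scatter. Replacing 3-fluorophenyl with 2-methoxyphenyl at the same place gives a 1.8-fold higher number from compound 2 to compound 4 (0.26 log units; within the scatter), so this place does not separate those two groups. Nothing available explains either step.

On these data alone, whether an amine or a carboxylic acid at this place would hold up in this cell read-out remains open. Also open, as far as these compounds go, is what the allyl group contributes, since compound 1 returns no number.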